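The source may hold more compounds than are shown below. What is called first, only, known or untested is meant among the compounds shown, and "the series" means these compounds.

Working notes on the series. Compound 1 `Cn1ncc2cc(-c3cnccc3/C=C/C(=O)N3CCOCC3)ccc21` gives 95% in an assay on a protein complex for inhibition of CDK8/Cyclin C (Homo sapiens), with a stated time of 1 h, tested at 10 uM; on this read-out lower numbers stand for less inhibition and higher numbers for more inhibition at the one concentration tested (going by the name of the read-out). Compound 2 `Cn1ncc2cc(-c3cnccc3/C=C/C(=O)O)ccc21` gives 102% in this assay; the step of a number 7 percentage points higher from compound 1 to compound 2 (within the scatter) is the change (hydroxy in place of morpholin-4-yl on a carbonyl carbon). Compound 3 `Cn1ccc2cc(-c3cnccc3/C=C/C(=O)N3CCOCC3)ccc21` gives 97% in this assay; the difference between the core of compound 3 and the core of compound 1 is not broken down here, and the three measured numbers all lie within the scatter of one another, so no order among them is claimed. Compound 4 `Cn1ccc2cc(-c3cnccc3/C=C/C(=O)O)ccc21` carries the same change on the core of compound 3, namely (hydroxy in place of morpholin-4-yl on a carbonyl carbon). Because the earlier step of a number 7 percentage points higher from compound 1 to compound 2 (within the scatter) stayed within the scatter, a step of about the same size, a number 4 percentage points higher from compound 3 to compound 4 (within the scatter), is expected here. Compound 4 is therefore estimated at 101% in this assay, expected to fall between 93% and 109%.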

Compound 4, a percentage reported as inhibition, at one concentration (the size of the read-out at that concentration, not a potency): 102%
Estimate against measurement, compound 4: 1 percentage points below; low and high end bracket the measured number.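

In this assay, morpholin-4-yl replaced by hydroxy on the carbonyl carbon gives a number 5 percentage points higher from compound 3 to compound 4 (within the scatter). Set beside the earlier step, the change carries over from one core to the other with no difference that can be read: the same change on two cores in this assay, a number 7 percentage points higher (within the scatter) from compound 1 to compound 2 and a number 5 percentage points higher (within the scatter) from compound 3 to compound 4, 2 percentage points apart, within the scatter of two such steps. This does not show that the change has any effect on either core. Each number is the size of the read-out at the one concentration tested, and neither step shows a stronger or weaker effect at that concentration.

Open, going by these compounds, are other groups on the carbonyl carbon, such as an acyclic amine in place of morpholin-4-yl or a methyl ester in place of the carboxylic acid, and a longer chain carrying the carbonyl. Also open, on these data alone, is whether the two steps would still agree at a lower test concentration.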